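The source may hold more compounds than are shown below. What is called first, only, known or untested is meant among the compounds shown, and "the series" means these compounds.

Compound 1 `Clc1ccc(-c2n[nH]cc2N2CCCNCC2)cc1` gives 1090 nM in an assay on isolated protein for binding affinity to 5-hydroxytryptamine receptor 6 (Homo sapiens); on this read-out lower numbers stand for stronger inhibition and higher numbers for weaker inhibition. Compound 2 `Fc1ccc(-c2n[nH]cc2N2CCCNCC2)cc1` gives 2290 nM in this assay, a step of a 2.1-fold higher number from compound 1 to compound 2 (0.32 log units; beyond the scatter) for the change (fluoro in place of chloro on an aromatic carbon). Compound 3 `Clc1ccccc1-c1n[nH]cc1N1CCNCC1` returns only a limit of this assay, > 10000 nM, as marked by the limit of > 10000 nM in this assay, at which 1 of the 3 values shown sits. How the core of compound 3 differs from the core of compound 1 is not broken down here. Compound 4 `Fc1ccccc1-c1n[nH]cc1N1CCNCC1` is not yet measured in this assay; it differs from compound 3 by fluoro in place of chloro on an aromatic carbon, the same kind of change as between compound 1 and compound 2, the place being ortho to a large group rather than para to a large group. Since compound 1 moved to compound 2 by a 2.1-fold higher number from compound 1 to compound 2 (0.32 log units; beyond the scatter), the expected step for compound 4 is a step that the limit leaves unreadable from compound 3 to compound 4, with the value expected to stay at the limit. Compound 4 is estimated at 20000 nM, between 8000 nM and 50000 nM.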

Compound 4, inhibition constant: 713 nM
Compound 4: middle estimate off by 28-fold (1.45 log units), on the high side, and the stated range ends above it.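

Fluoro in place of chloro, ortho to a large group, gives an at least 14-fold lower number from compound 3 to compound 4 (1.14 log units; beyond the scatter) in this assay. This change does not carry from one core to the other with a fixed size or direction: the same change on two cores in this assay, a 2.1-fold higher number (0.32 log units; beyond the scatter) from compound 1 to compound 2 and an at least 14-fold lower number (1.14 log units; beyond the scatter) from compound 3 to compound 4, at least 29-fold (1.46 log units) apart, beyond the scatter of two such steps

The compounds do not show whether the core or the place of the halogen sets this difference, and compound 3 stands only at a limit of the assay: the limit of > 10000 nM in this assay, at which 1 of the 4 values shown sits.

Still open, from the compounds shown here alone, is how chloro and fluoro compare when each place is tested on a single core. Also open, going by these compounds, is how a methyl or a methoxy at the same place on the core of compound 3 would read against fluoro.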